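This account rests on a few compounds, and the source may have more. Where it says the series, first, only, none or still open, it means among the compounds named here.

In a functional assay on HeLa cells (Homo sapiens) for antiproliferative activity, read by CCK-8 assay, with a stated time of 72 h (a lower number here means a stronger inhibitor, a higher number a weaker inhibitor), the measured compounds gave:

Compound 1 `Cc1ccccc1C(=O)Nc1cccc(-c2oc3cc(-c4ccc(F)cc4)ccc3c(=O)c2O)c1`: 11900 nM
Compound 2 `Cc1cc(C(=O)Nc2cccc(-c3oc4cc(-c5ccc(F)cc5)ccc4c(=O)c3O)c2)ccc1F`: 18900 nM
Compound 3 `O=C(Nc1cccc(-c2oc3cc(-c4ccc(F)cc4)ccc3c(=O)c2O)c1)c1cc(F)cc(F)c1`: 3380 nM

Compound 3 stands lowest of the three, and both other compounds lie beyond the scatter from it, so it is the strongest inhibitor measured here. Compound 4 `CCCc1ccc(C(=O)Nc2cccc(-c3oc4cc(-c5ccc(F)cc5)ccc4c(=O)c3O)c2)cc1` differs from compound 3 by 4-propylphenyl in place of 3,5-difluorophenyl on a carbonyl carbon. Within the data shown here, two measured steps bear on this change: a 3.5-fold lower number from compound 1 to compound 3 (0.55 log units; beyond the scatter) and a 5.6-fold lower number from compound 2 to compound 3 (0.75 log units; beyond the scatter). In each, a methyl-bearing phenyl was replaced by the 3,5-difluorophenyl and the number fell beyond the scatter. Compound 4 returns to an alkyl-bearing phenyl, so a move back toward the numbers of compound 1 and compound 2 is expected, a step of a 3.3-fold higher number from compound 3 to compound 4 (0.51 log units; beyond the scatter). Compound 4 is therefore estimated at 11000 nM in this assay, with a range from 3500 nM to 35000 nM.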

Compound 4, half-maximal inhibitory concentration: 8790 nM
Beside the measured number, compound 4's estimate is 1.3-fold (0.10 log units) above it; low and high end bracket the measured number.
By their numbers in this assay, from the lowest: compound 3; then compounds 4, 1 and 2 (each within the scatter of the next, the first and the last beyond it).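

At this carbonyl carbon, a propyl chain keeps activity in this assay, yet the 3,5-difluorophenyl of compound 3 still gives the lowest number (a 2.6-fold higher number from compound 3 to compound 4 (0.42 log units; beyond the scatter)). The 4-propylphenyl ring cannot be told apart from the 2-methylphenyl ring (a 1.4-fold lower number from compound 1 to compound 4 (0.13 log units; within the scatter)) but gives a lower number than the 4-fluoro-3-methylphenyl ring (a 2.2-fold lower number from compound 2 to compound 4 (0.33 log units; beyond the scatter)). Nothing measured here explains these differences. Still open, from the compounds shown here alone, is how a phenyl ring carrying an amine, a carboxylic acid or a chain longer than propyl would compare with compound 3.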